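The source may hold more compounds than are shown below. What is called first, only, known or untested is meant among the compounds shown, and "the series" means these compounds.

Working notes on the series. In an assay on HeLa cells for displacement of a labelled ligand from adenosine receptor A3 (Homo sapiens), with a stated time of 180 min, tested at 1 uM (a higher number here means more inhibition at the concentration tested (going by the name of the read-out), a lower number less inhibition), compound 1 `CCOC(=O)C1=C(C)N/C(=N\C#N)NC1c1cccs1` gives 3%. Among the measured compounds shown here, compound 2 `CC1=C(C(=O)OC(C)C)C(C2CCCC2)NC(=O)N1` gives 7% in this assay, within the scatter of compound 1, so the two sit together at the low end; compound 3 `CC1=C(C(=O)OC(C)C)C(c2cccs2)N/C(=N/C#N)N1` gives 27%, and the only one-place step recorded, a number 24 percentage points higher from compound 1 to compound 3 (beyond the scatter), concerns the ester and not the aryl group. Compound 4 `CCOC(=O)C1=C(C)N/C(=N\C#N)NC1c1ccccc1` differs from compound 1 by phenyl in place of thiophen-2-yl on a saturated ring carbon. For the measured compounds named here, no measured step covers an aryl exchange of this kind, and compounds 2 and 3 differ in two places, so their values alone say only that a cyclopentyl analogue also sits low. Compound 4 is therefore expected to show a number 3 percentage points higher from compound 1 to compound 4 (within the scatter), nothing beyond the scatter. The estimate for compound 4 is 6%, in the range -5% to 22%.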

Compound 4, a percentage reported as inhibition, at one concentration (the size of the read-out at that concentration, not a potency): 13%
For compound 4 the middle estimate is 7 percentage points below the measured one; the measured number falls inside the stated range.
By their numbers in this assay, from the lowest: compounds 1, 2 and 4 (each within the scatter of the next); then compound 3.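

In this assay, phenyl in place of thiophen-2-yl on the saturated ring carbon gives a number 10 percentage points higher from compound 1 to compound 4 (within the scatter), the first aryl exchange read at this position. With the ethoxycarbonyl group kept, the read-out does not separate the two aromatic rings, so the sulfur-containing five-membered ring is not needed to stay at this level. Nothing measured accounts for this result.

From the compounds shown here alone, whether a pyridyl ring or a methoxy-bearing phenyl at this position would move the number beyond the scatter stays open. So does whether the same exchange reads alike with the ester of compound 3.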